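Moving a Sulfonamide Aryl Substituent: From Compound 2 to 3

The source may report more compounds than this note shows. Statements on the series, on what has been measured and on what is new or still open speak of the compounds shown alone.

- compound 1 `Cc1ccccc1NS(=O)(=O)c1cccc(CCCCCCNC(=O)/C=C/c2cccnc2)c1`: 0.456 nM
- compound 2 `Cc1cccc(NS(=O)(=O)c2cccc(CCCCCCNC(=O)/C=C/c3cccnc3)c2)c1`: 4.78 nM

In a functional assay on K562 cells (Homo sapiens) for inhibition, read by CCK-8 assay, with a stated time of 72 h (on this read-out higher numbers stand for weaker inhibition and lower numbers for stronger inhibition), compound 2 holds the higher of the two numbers at 4.78 nM, while compound 1 gives 0.456 nM. The next compound to be read is compound 3 `CCc1ccc(NS(=O)(=O)c2cccc(CCCCCCNC(=O)/C=C/c3cccnc3)c2)cc1`. It differs from compound 2 on a sulfonamide nitrogen, with 4-ethylphenyl in place of 3-methylphenyl on a sulfonamide nitrogen.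

Within the data shown here, only one measured step bears on this change. That step, a 10-fold higher number from compound 1 to compound 2 (1.02 log units; beyond the scatter), is large and lies beyond the scatter, and it came from replacing 2-methylphenyl with 3-methylphenyl at the same place. It shows that a small change in this group can move the number considerably in this assay. However, no measured compound carries a 4-ethylphenyl group, so the data do not indicate a direction. No step beyond the scatter is therefore expected, although a wide margin remains sensible. The expected change is a 1.4-fold lower number from compound 2 to compound 3 (0.14 log units; within the scatter). For compound 3 the estimated value is 3.5 nM, with an expected range from 0.9 nM to 14 nM.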

Compound 3, half-maximal inhibitory concentration: 3.89 nM
The estimate for compound 3 lay 1.1-fold (0.05 log units) below the measured number, within the range that was stated.
By their numbers in this assay, from the lowest: compound 1; then compounds 3 and 2 (each within the scatter of the next).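

In this assay, putting 4-ethylphenyl in place of 3-methylphenyl on a sulfonamide nitrogen gives a 1.2-fold lower number from compound 2 to compound 3 (0.09 log units; within the scatter) and so leaves these two groups indistinguishable on this read-out. The second comparison, an 8.5-fold higher number from compound 1 to compound 3 (0.93 log units; beyond the scatter) and thus a modest step, means that compound 1 now stands apart from two compounds instead of one. Among the three groups shown at this place, only the 2-methylphenyl of compound 1 gives a number beyond the scatter of the others, and no measurement at hand accounts for this separation.

Still open, from the compounds shown here alone, is whether 2-ethylphenyl, 2-chlorophenyl, 2-methoxyphenyl or plain phenyl on the sulfonamide nitrogen would fall with compound 1 or with compound 2 and compound 3, which would show how far the low number depends on the 2-methylphenyl group itself. The compounds shown also leave open how 4-methylphenyl and 3-ethylphenyl would read, and these two groups would separate the effect of moving the substituent from that of lengthening it, which compound 3 changes together.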